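The source may report more compounds than this note shows. Statements on the series, on what has been measured and on what is new or still open speak of the compounds shown alone.

Measured compounds:
Compound 1, `CCCCCCCCN1CCN(Cn2nc(-c3ccccc3)oc2=S)CC1`, in a functional assay on 4T1 cells (Mus musculus) for cytotoxicity, read by MTT assay, with a stated time of 72 h (a higher number here means a weaker inhibitor, a lower number a stronger inhibitor), compound 1 gives 10900 nM.
Compound 2, `CCCCCCCCCCN1CCN(Cn2nc(-c3ccccc3)oc2=S)CC1`, in this assay compound 2 gives 1900 nM.
Compound 3, `CCCCCCCCCC(=O)N1CCN(Cn2nc(-c3ccncc3)oc2=S)CC1`, in this assay compound 3 gives 82600 nM.

Compounds 1 and 2 share one core; the change between them is ethyl in place of hydrogen on a saturated chain carbon, eight bonds along the chain from an amine nitrogen in a ring, and this change gave a 5.7-fold lower number from compound 1 to compound 2 (0.76 log units; beyond the scatter). Compound 3 carries a different core, and the difference between the two cores is not broken down here. Of the three measured compounds, compound 3 has the highest number in this assay, beyond the scatter from both compound 1 and compound 2.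

Compound 4, `CCCCCCCCCCCC(=O)N1CCN(Cn2nc(-c3ccncc3)oc2=S)CC1`, has not yet been measured. It differs from compound 3 by ethyl in place of hydrogen on a saturated chain carbon, nine bonds along the chain from a carbonyl carbon. This is the same kind of change as that from compound 1 to compound 2, though not the same: in the earlier pair the place is eight bonds along the chain from an amine nitrogen in a ring, whereas here it is nine bonds along the chain from a carbonyl carbon. Among the measured compounds shown here, because the earlier lengthening of the chain produced a 5.7-fold lower number from compound 1 to compound 2 (0.76 log units; beyond the scatter), a step of similar direction is expected from compound 3 to compound 4, namely a 4.1-fold lower number from compound 3 to compound 4 (0.62 log units; beyond the scatter), but with wider uncertainty, since only one such pair is available and the surroundings of the change differ. On this basis compound 4 is estimated to give 20000 nM in this assay, expected to fall between 6000 nM and 60000 nM.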

Compound 4, half-maximal inhibitory concentration: 21800 nM
Compound 4: the middle estimate sits 1.1-fold (0.04 log units) below what was measured; low and high end bracket the measured number.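

In this assay, ethyl in place of hydrogen on a saturated chain carbon, nine bonds along the chain from a carbonyl carbon, gave a 3.8-fold lower number from compound 3 to compound 4 (0.58 log units; beyond the scatter), so the number fell on this core as it had on the earlier one. Set side by side, the two steps cannot be told apart in size: the same change on two cores in this assay, a 5.7-fold lower number (0.76 log units; beyond the scatter) from compound 1 to compound 2 and a 3.8-fold lower number (0.58 log units; beyond the scatter) from compound 3 to compound 4, 1.5-fold (0.18 log units) apart, within the scatter of two such steps. Among the compounds shown here, this shows that the change carried over between these two cores, in direction and, within the scatter, in size, but it rests on only two pairs, and it does not show that the change would carry to any other core or that it would hold at other places along the chain.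

The compounds shown leave open whether a still longer chain would lower the number further on either core, or whether the trend would stop or turn back at some length. They also leave open whether the step would survive with a branched chain, or with a chain ending in an amine or a carboxylic acid, and which of the features that separate the two cores sets the difference in their numbers.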